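Cytotoxicity notes: from compound 2 to compound 4

The source may hold more compounds than are shown below. What is called first, only, known or untested is meant among the compounds shown, and "the series" means these compounds.

Measured in an ADME assay on PC-3 cells (Homo sapiens) for cytotoxicity, read by WST assay, tested at 100 uM; a higher number here means more inhibition at the concentration tested (going by the name of the read-out), a lower number less inhibition:
compound 1 `O=C(Nc1cccc(Oc2ccccn2)c1)C1CCCN(C(=O)c2cc(C(F)(F)F)cc(C(F)(F)F)c2)C1` gives 0%
compound 2 `Cc1nc(-c2cccc(C(=O)N3CCCC(C(=O)Nc4ccc(Cl)cc4)C3)c2)no1` gives 0%
compound 3 `COc1cccc(NC(=O)C2CCCN(C(=O)c3cc(C(F)(F)F)cc(C(F)(F)F)c3)C2)c1` gives 0%

Going by the values given here, compound 2 stands level with compounds 1 and 3 in this assay; all three sit at the same printed value, and no step among them goes beyond the scatter. Compound 2 differs from compounds 1 and 3 in more than one place, so only the two values are to be compared, and they agree.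

The unmeasured compound 4 `Cc1nc(-c2cccc(C(=O)N3CCCC(C(=O)Nc4ccc(Cl)cc4)C3)c2)cs1` differs from compound 2 by 2-methyl-1,3-thiazol-4-yl in place of 5-methyl-1,2,4-oxadiazol-3-yl on an aromatic carbon.

Among the compounds with values here, the only single-point step measured so far is no change at the digits printed from compound 1 to compound 3 (within the scatter), which concerns a group on an oxygen rather than a five-membered aromatic ring on an aromatic carbon. It bears on the present step only in the general sense that, in this assay, a change of a peripheral group left the read-out where it was. Nothing measured yet speaks to an exchange of one five-membered aromatic ring for another.

For compound 4 in this assay the step of a number 2 percentage points higher from compound 2 to compound 4 (within the scatter) is expected to be none beyond the scatter. Compound 4 is therefore estimated at 2%, with a range from 0% to 15%, which is a guess anchored only in the flat values of compounds 1, 2 and 3.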

Compound 4, a percentage reported as inhibition, at one concentration (the size of the read-out at that concentration, not a potency): 1%
Beside the measured number, compound 4's estimate is 1 percentage points above it; the range from low to high includes it.
By their numbers in this assay, from the lowest: compounds 1, 2, 3 and 4 (each within the scatter of the next).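

In this assay, going by these compounds alone, the exchange of 5-methyl-1,2,4-oxadiazol-3-yl for 2-methyl-1,3-thiazol-4-yl, on an aromatic carbon meta to a large group, reads as a number 1 percentage points higher from compound 2 to compound 4 (within the scatter) and is the first measured exchange of one five-membered aromatic ring for another. At this position, therefore, the read-out stays within the scatter when the ring's hetero atoms and its count of hydrogen-bond acceptors change, while the number of heavy atoms, the absence of donors and the absence of net charge remain the same, so the flat picture given earlier by a change on an oxygen now extends to a ring on an aromatic carbon. No available measurement offers an explanation for this flat result.

All the compounds shown sit close together at the low end of the read-out at a single tested concentration, so they give no indication of which changes, if any, would raise inhibition. On these data alone, it remains open whether a group of a different kind at this position, such as a carboxylic acid, a primary amine or a longer alkyl chain in place of the five-membered ring, would move the read-out beyond the scatter.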